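Swapping pyridin-3-yl for pyridin-4-yl: what to expect

The source may report more compounds than this note shows. Statements on the series, on what has been measured and on what is new or still open speak of the compounds shown alone.

Measured in an in vitro assay on BTI-TN-5B1-4 cells for inhibition of Amine oxidase [flavin-containing] A (Homo sapiens), read by Amplex Red, with a stated time of 15 min, tested at 100 uM; on this read-out higher numbers stand for more inhibition at the one concentration tested (going by the name of the read-out) and lower numbers for less inhibition:
compound 1 `Fc1ccc(-c2csc(N/N=C\c3cccnc3)n2)cc1` gives 40%
compound 2 `C/C(=N/Nc1nc(-c2ccc(F)cc2)cs1)c1cccnc1` gives 40%
compound 3 `Fc1ccc(-c2csc(N/N=C\c3ccncc3)n2)cc1` gives 40%

Compound 1 and compound 3 share one core and differ only in the pyridyl group: pyridin-4-yl in place of pyridin-3-yl on a carbon with a double bond to nitrogen. The step this change made in this assay is no change at the digits printed from compound 1 to compound 3 (within the scatter), so within the usual scatter the two compounds read alike.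

Compound 2 carries a different core; how it differs from compound 1 is not broken down here. Its value in this assay sits level with those of compound 1 and compound 3, all three within the scatter of one another, so no order among them can be read from these numbers.

Compound 4 `C/C(=N/Nc1nc(-c2ccc(F)cc2)cs1)c1ccncc1` has not yet been measured in this assay. It arises from compound 2 by the change (pyridin-4-yl in place of pyridin-3-yl on a carbon with a double bond to nitrogen). Among the measured compounds shown here, this is the same kind of change as that from compound 1 to compound 3, though not the same: in compound 2 the carbon with a double bond to nitrogen has as its other neighbours the double-bonded nitrogen and a saturated chain carbon, whereas in compound 1 its only other neighbour is the double-bonded nitrogen.

Resting on the step of no change at the digits printed from compound 1 to compound 3 (within the scatter), the step from compound 2 to compound 4 in this assay is expected to be no change at the digits printed from compound 2 to compound 4 (within the scatter). Compound 4 is therefore estimated at 40%, with a range from 28% to 52%.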

Compound 4, a percentage reported as inhibition, at one concentration (the size of the read-out at that concentration, not a potency): 40%
For compound 4 middle estimate and measured number coincide at the digits printed; measured number inside the range.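

In this assay, putting pyridin-4-yl in place of pyridin-3-yl on the core of compound 2 gives this result: no change at the digits printed from compound 2 to compound 4 (within the scatter). Set beside the same change on the core of compound 1, the outcome carries over from one core to the other: the same change on two cores in this assay, no change at the digits printed (within the scatter) from compound 1 to compound 3 and no change at the digits printed (within the scatter) from compound 2 to compound 4, 0 percentage points apart, within the scatter of two such steps This shows only that the two pairs agree in this one read-out, at the one concentration tested; it does not show that the two pyridyl groups are interchangeable on other cores, and, as the read-out is not a potency, it cannot exclude a difference in potency between the members of either pair.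

Going by these compounds, all four compounds carry a pyridyl group on the carbon with a double bond to nitrogen, so what pyridin-2-yl, a plain phenyl or a pyridyl ring bearing an amine or a carboxylic acid would give there remains open. Also open, on these data alone, is whether the two pyridyl groups would still read alike with a longer chain in place of the saturated chain carbon found in compound 2 and compound 4.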